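The source may report more compounds than this note shows. Statements on the series, on what has been measured and on what is new or still open speak of the compounds shown alone.

Working notes on the series, read in a functional assay on HeLa cells (Homo sapiens) for antiproliferative activity, read by MTT assay, with a stated time of 72 h; a lower number here means a stronger inhibitor, a higher number a weaker inhibitor. Compound 1 `O=c1cc(CSC(=S)N2CCCCC2)oc2cc(Cl)ccc12` gives only a limit in this assay, > 25000 nM. Among the measured compounds shown here, compound 2 `COc1ccc2occ(CSC(=S)N3CCOCC3)c(=O)c2c1` gives 9500 nM in this assay, the single number measured so far. For the measured compounds named here, the one other value shown, that of compound 1, is a limit. Compound 3 `COc1ccc2occ(CSC(=S)N3CCCCC3)c(=O)c2c1` carries piperidin-1-yl in place of morpholin-4-yl on a thiocarbonyl carbon. Going by the values given here, no measured pair isolates this change; compound 1 also bears piperidin-1-yl yet differs elsewhere, and its limit alone says nothing about the step. The step from compound 2 to compound 3 is expected to stay small, a 1.3-fold higher number from compound 2 to compound 3 (0.10 log units; within the scatter), within the scatter or a slight weakening. Compound 3 is estimated at 12000 nM, between 4000 nM and 35000 nM.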

Compound 3, half-maximal inhibitory concentration: 3500 nM
Compound 3: the middle estimate sits 3.4-fold (0.54 log units) above what was measured; the measured number lies below the stated range.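

In this assay the change to piperidin-1-yl on a thiocarbonyl carbon gives a 2.7-fold lower number from compound 2 to compound 3 (0.43 log units; beyond the scatter). Among the compounds shown here, this is the first step that can be read, and it shows that this position responds to the change and that morpholin-4-yl is not required on the core shared by compound 2 and compound 3.

On these data alone, whether other amines, such as pyrrolidin-1-yl, diethylamino or 4-methylpiperazin-1-yl, would extend this step remains open. Compound 1 remains a limit, so piperidin-1-yl cannot be judged on its core: the limit of > 25000 nM in this assay, at which 1 of the 3 values shown sits.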